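From furan-2-yl to furan-3-yl at the solubility limit

The source may hold more compounds than are shown below. What is called first, only, known or untested is meant among the compounds shown, and "the series" means these compounds.

Three compounds were measured in a physicochemical assay for solubility, read by HPLC, with a stated time of 24 h (on this read-out higher numbers stand for higher solubility and lower numbers for lower solubility), with these results:

Compound 1 `CC(C)(C)c1[nH]cnc1/C=c1\[nH]c(=O)/c(=C/c2cccc(C(=O)c3cccnc3)c2)[nH]c1=O` gives < 0.1 ug/mL as a limit
Compound 2 `CC(C)(C)c1[nH]cnc1/C=c1\[nH]c(=O)/c(=C/c2cccc(C(=O)c3ccncc3)c2)[nH]c1=O` gives < 0.1 ug/mL as a limit
Compound 3 `CC(C)(C)c1[nH]cnc1/C=c1\[nH]c(=O)/c(=C/c2cccc(C(=O)c3ccco3)c2)[nH]c1=O` gives < 0.1 ug/mL as a limit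

Compound 3 therefore has no exact number, and it stands with the others, as the limit of < 0.1 ug/mL in this assay, at which 3 of the 3 values shown sit, shows. Compound 4 `CC(C)(C)c1[nH]cnc1/C=c1\[nH]c(=O)/c(=C/c2cccc(C(=O)c3ccoc3)c2)[nH]c1=O` differs from compound 3 in one place, with furan-3-yl in place of furan-2-yl on a carbonyl carbon, counted as furan-3-yl in place of furan-2-yl on a carbonyl carbon and made of the same atoms joined differently. The nearest evidence comes from swaps on that same carbonyl carbon, namely a step that the two limits leave unreadable from compound 1 to compound 3 and a step that the two limits leave unreadable from compound 2 to compound 3 along with a step that the two limits leave unreadable from compound 1 to compound 2 in this small family. None of these has a readable size, so they give no direction. Since compound 3 gives < 0.1 ug/mL as a limit, the same limit is the likeliest report for compound 4. The expected change is a step that the limit leaves unreadable from compound 3 to compound 4 with no clear direction and nothing beyond the usual scatter. For compound 4 the estimated solubility is 0.06 ug/mL with an expected range from 0.02 ug/mL to 0.2 ug/mL when it is measured.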

Compound 4, solubility: < 0.1 ug/mL
Compound 4 gave a limit, no number; the forecaster's own chance of this, stated with the estimate: 85%; the middle value lies beyond the limit too.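

In this assay compound 4 gives < 0.1 ug/mL, which is a limit and not a number. No step among compound 1, compound 2, compound 3 and compound 4 can be read: the limit of < 0.1 ug/mL in this assay, at which 4 of the 4 values shown sit.

From the compounds shown here alone, whether the group on the carbonyl carbon changes solubility at all, and in which direction, stays open.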